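The source may report more compounds than this note shows. Statements on the series, on what has been measured and on what is new or still open speak of the compounds shown alone.

Measured so far in a functional assay on aorta for antagonist activity at Alpha-1D adrenergic receptor (Rattus norvegicus); on this read-out lower numbers stand for tighter binding and higher numbers for weaker binding:

compound 1, `COc1ccccc1N1CCN(CCCNc2ncc(C#N)cc2C(=O)N(C)C)CC1` — 20 nM
compound 2, `COc1ccccc1N1CCN(CCCNc2ccncc2C(=O)N(C)C)CC1` — 50.1 nM
compound 3, `CN(C)C(=O)c1cccnc1NCCCN1CCN(c2ccccc2)CC1` — 15.9 nM

Compound 3 stands at the lowest of the three numbers. Its nearest neighbour is compound 1, whose number is higher by an amount that lies within the usual scatter of this assay, so the two cannot be ranked against each other. Compound 2 sits furthest away, with a number higher than that of compound 3 by a margin beyond the scatter.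

The next compound in the series is compound 4, `CN(C)C(=O)c1cccnc1NCCCN1CCN(c2ccccc2C(F)(F)F)CC1`. Relative to compound 3 the change is trifluoromethyl in place of hydrogen on an aromatic carbon. Read one bond further out, this is phenyl to 2-(trifluoromethyl)phenyl. Within the data shown here, no pair among the measured compounds differs in this one place alone, so nothing measured here speaks directly to the size of such a step. The closest comparison, compound 1 against compound 3, carries a second change as well and the two numbers lie within the scatter of one another.

Expectation: a small step, of uncertain direction, most likely not beyond the scatter, with a slight lean toward a higher number. For compound 4 in this assay the estimate is 25 nM, within a range of 8 nM to 80 nM. This estimate means a step from compound 3 to compound 4 of a 1.6-fold higher number from compound 3 to compound 4 (0.20 log units; within the scatter).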

Compound 4, dissociation constant: 316 nM
Compound 4: middle estimate off by 13-fold (1.10 log units), on the low side; measured number outside the range, above it.
By their numbers in this assay, from the lowest: compounds 3 and 1 (each within the scatter of the next); then compound 2; then compound 4.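

In this assay, the change from phenyl to 2-(trifluoromethyl)phenyl gives a 20-fold higher number from compound 3 to compound 4 (1.30 log units; beyond the scatter). Among these compounds, this is the first step that differs in one place alone, and its size shows that this aromatic carbon, ortho to a large group, is far from indifferent to substitution on this read-out. Nothing at hand bears on what lies behind the step.

Compounds 1 and 2 each differ from compound 3 in more than one place, so the methoxy group they carry cannot be read against this step. From the compounds shown here alone, whether a methyl group or a chlorine atom on the same carbon brings a step of similar size stays open, as does the outcome of trifluoromethyl on another carbon of the phenyl.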